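Butylamino in place of cyclopropylamino on the shared core

This account rests on a few compounds, and the source may have more. Where it says the series, first, only, none or still open, it means among the compounds named here.

Compound 2 `Nc1nc(NC2CC2)c2ncn(/C=C3/CC3(CO)CO)c2n1` carries cyclopropylamino on the shared core. In an ADME assay on HFF cells (Homo sapiens) for cytotoxicity, with a stated time of 8 days (a lower number here means that less compound is tolerated, a higher number that more compound is tolerated), compound 2 gives only a limit of the assay, > 300000 nM. Compound 1 `CCOc1nc(N)nc2c1ncn2/C=C1/CC1(CO)CO`, the ethoxy analogue, likewise reaches only the limit > 300000 nM. Compound 3 `CCCCCCCCSc1nc(N)nc2c1ncn2/C=C1/CC1(CO)CO`, with octylsulfanyl, also stops at the limit > 300000 nM. All three values thus sit at the limit of > 300000 nM in this assay, at which 3 of the 3 values shown sit, and the steps a step that the two limits leave unreadable from compound 1 to compound 2, a step that the two limits leave unreadable from compound 2 to compound 3 and a step that the two limits leave unreadable from compound 1 to compound 3 cannot be read. Compound 4 `CCCCNc1nc(N)nc2c1ncn2/C=C1/CC1(CO)CO` is not yet measured; it differs from compound 2 by butyl in place of cyclopropyl on a nitrogen on an aromatic ring. Within the data shown here, no measured step bears readably on this change, and the shared position of compound 1, compound 2 and compound 3 gives no direction to expect. Compound 4 is therefore expected to sit again at the limit, with a number no higher from compound 2 to compound 4 (the limit leaves the size open) expected. The estimate for compound 4 is 300000 nM, ranging from 100000 nM to 1000000 nM.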

Compound 4, half-maximal cytotoxic concentration: > 300000 nM
Compound 4 ended at the assay's limit; the forecaster's own chance of this, stated with the estimate: 85%; the middle value lies on the limit itself.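

The steps linking compound 4 to compound 1, compound 2 and compound 3 in this assay cannot be read, since all four values are limits: the limit of > 300000 nM in this assay, at which 4 of the 4 values shown sit. As far as these compounds go, whether these four compounds differ at all in this assay remains open.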